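A few compounds are considered here, and "the series" means these few. Any claim that something is new, unique, unknown or untested is made for them only; others in the source may bear on it.

Compound 1 `COc1ccccc1-n1cc(COC(=O)/C(C)=C/CC/C(C)=C/CC/C(C)=C/CC[C@@H]2[C@@]3(C)CCC(=O)C(C)(C)[C@H]3CC[C@@]2(C)O)nn1` gives > 150000 nM (a limit)
Compound 2 `C#CCOC(=O)/C(C)=C/CC/C(C)=C/CC/C(C)=C/CC[C@@H]1[C@@]2(C)CCC(=O)C(C)(C)[C@H]2CC[C@@]1(C)O` gives 45100 nM

Going by the values given here, in a functional assay on A549 cells (Homo sapiens) for antiproliferative activity, read by MTT assay, with a stated time of 48 h (on this read-out higher numbers stand for weaker inhibition and lower numbers for stronger inhibition), compound 2 gives 45100 nM as the only actual number so far. For compound 1 the entry > 150000 nM is a limit of the assay and not a number. Compound 3 `C/C(=C\CC/C(C)=C/CC[C@@H]1[C@@]2(C)CCC(=O)C(C)(C)[C@H]2CC[C@@]1(C)O)CC/C=C(\C)C(=O)OCc1cn(-c2ccccc2C)nn1` differs from compound 2 by 1-(2-methylphenyl)-1H-1,2,3-triazol-4-yl in place of ethynyl on a saturated chain carbon bound to an oxygen next to a carbonyl group with 1-(2-methylphenyl)-1H-1,2,3-triazol-4-yl in place of ethynyl on a saturated chain carbon bound to an oxygen next to a carbonyl group. This brings it closer in structure to compound 1, whose > 150000 nM is a limit, so weaker inhibition is expected in this assay for compound 3. The expected 2.2-fold higher number from compound 2 to compound 3 (0.35 log units; beyond the scatter) is a modest one. Compound 3 is estimated at 100000 nM within a range of 35000 nM to 200000 nM as expected bounds.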

Compound 3, half-maximal inhibitory concentration: > 150000 nM
Compound 3 was reported as a limit (the forecaster's own chance of this, stated with the estimate: 45%); middle value at least 1.5-fold (0.17 log units) away from the limit.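

In this assay, placing 1-(2-methylphenyl)-1H-1,2,3-triazol-4-yl in place of ethynyl on a saturated chain carbon bound to an oxygen next to a carbonyl group gives an at least 3.3-fold higher number from compound 2 to compound 3 (0.52 log units; beyond the scatter). Going by these compounds alone, this is the first readable step at this position, and it shows that this change weakens inhibition, by an amount whose full size remains unknown. The step for methyl in place of methoxy on an aromatic carbon cannot be read, because compound 1 and compound 3 both sit at a limit: the limit of > 150000 nM in this assay, at which 2 of the 3 values shown sit.

From the compounds shown here alone, it remains open whether a simple amine or a plain phenyl in place of ethynyl at this carbon would keep the inhibition seen with compound 2.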